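A few compounds are considered here, and "the series" means these few. Any claim that something is new, unique, unknown or untested is made for them only; others in the source may bear on it.

In a functional assay on PC-3 cells (Homo sapiens) for antiproliferative activity, read by MTT assay, with a stated time of 48 h (a higher number here means a weaker inhibitor of growth, a lower number a stronger inhibitor of growth), three compounds built on a shared core have been measured. Compound 1 `CCCCCN(Cc1ccc(C(=O)NO)cc1)c1ncc(-c2ccc(C)cc2)s1`, with pentyl on the nitrogen on an aromatic ring, gives 5060 nM. Compound 2 `Cc1ccc(-c2cnc(N(Cc3ccc(C(=O)NO)cc3)CC(C)C)s2)cc1`, with isobutyl there, gives 9340 nM, and a 1.8-fold higher number from compound 1 to compound 2 (0.27 log units; within the scatter) separates the two. Compound 3 `Cc1ccc(-c2cnc(N(Cc3ccc(C(=O)NO)cc3)C(C)C)s2)cc1`, with isopropyl there, gives 1150 nM, the lowest number of the three. It stands apart from both others, with a 4.4-fold lower number from compound 1 to compound 3 (0.64 log units; beyond the scatter) and an 8.1-fold lower number from compound 2 to compound 3 (0.91 log units; beyond the scatter).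

Compound 4 `Cc1ccc(-c2cnc(N(CCCOc3ccccc3)Cc3ccc(C(=O)NO)cc3)s2)cc1` is the next step from compound 3: 3-phenoxypropyl in place of isopropyl on a nitrogen on an aromatic ring. In words, 3-phenoxypropyl replaces isopropyl on a nitrogen on an aromatic ring. The closest evidence is those same two steps read in reverse, since both other groups sit at higher numbers than isopropyl. For the measured compounds named here, no measured compound carries a ring or an oxygen in this group, so the guidance is loose.

A modest move to a higher number is therefore expected, and the estimated change is a 3.0-fold higher number from compound 3 to compound 4 (0.48 log units; beyond the scatter). For compound 4 the expected value is 3500 nM, within an estimated range of 1000 nM to 12000 nM.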

Compound 4, concentration for 50% growth inhibition: 17500 nM
For compound 4 the middle estimate is 5.0-fold (0.70 log units) below the measured one; the measured number lies above the stated range.
By their numbers in this assay, from the lowest: compound 3; then compounds 1, 2 and 4 (each within the scatter of the next, the first and the last beyond it).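

In this assay, for the compounds shown here, 3-phenoxypropyl brings the first ring and the first oxygen into this group on the nitrogen, and it gives a 15-fold higher number from compound 3 to compound 4 (1.18 log units; beyond the scatter), the largest step so far at this position. Set against the saturated chains, the same group gives a 1.9-fold higher number from compound 2 to compound 4 (0.27 log units; within the scatter), so compound 4 cannot be told apart from compound 2, and a 3.5-fold higher number from compound 1 to compound 4 (0.54 log units; beyond the scatter), which leaves compound 3 with isopropyl at the lowest number of the four. Nothing available explains why this longer group raises the number.

Going by these compounds, it stays open whether a small ring such as cyclopropyl or a branched group such as tert-butyl would fall below compound 3. Also open, on these data alone, is whether a shorter chain carrying phenoxy, or an amine or a carboxylic acid at the chain end, would change the reading.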